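A few compounds are considered here, and "the series" means these few. Any claim that something is new, unique, unknown or untested is made for them only; others in the source may bear on it.

Of the compounds shown here, three that share one core have been measured in an assay on isolated protein (Cavia porcellus) with Sigma non-opioid intracellular receptor 1 (Homo sapiens) as the target, read by radioligand binding; a lower number here means a stronger inhibitor, a higher number a weaker inhibitor. Compound 1 `CN(C)CCCCCCCOc1ccc2oc(-c3ccccc3)cc(=O)c2c1` gives 165 nM, compound 2 `CN(C)CCCCCCCCCCOc1ccc2oc(-c3ccccc3)cc(=O)c2c1` gives 297 nM, and compound 3 `O=c1cc(-c2ccccc2)oc2ccc(OCCCCCCN3CCCCC3)cc12` gives 101 nM. Compound 3 sits within the scatter of compound 1, with a 1.6-fold lower number from compound 1 to compound 3 (0.21 log units; within the scatter), while a 2.9-fold lower number from compound 2 to compound 3 (0.47 log units; beyond the scatter) lies beyond it. Compound 4 `O=c1cc(-c2cccnc2)oc2ccc(OCCCCCCN3CCCCC3)cc12` differs from compound 3 by pyridin-3-yl in place of phenyl on an aromatic carbon. Within the data shown here, every measured step, including a 1.8-fold higher number from compound 1 to compound 2 (0.26 log units; within the scatter), alters only the amine end of the chain and leaves the phenyl untouched, so no measured step bears on this change. The number for compound 4 in this assay is therefore expected to stay close to that of compound 3, so that a 1.5-fold higher number from compound 3 to compound 4 (0.17 log units; within the scatter) is expected to lie within the scatter. The estimate for compound 4 is 150 nM, ranging from 60 nM to 400 nM.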

Compound 4, half-maximal inhibitory concentration: 119 nM
Beside the measured number, compound 4's estimate is 1.3-fold (0.10 log units) above it; low and high end bracket the measured number.
By their numbers in this assay, from the lowest: compounds 3, 4, 1 and 2 (each within the scatter of the next, the first and the last beyond it).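

In this assay, pyridin-3-yl in place of phenyl on the aromatic carbon next to the ring oxygen gives a 1.2-fold higher number from compound 3 to compound 4 (0.07 log units; within the scatter) and so stays within the scatter, the first step shown that alters this end of the molecule rather than the amine end of the chain. In this one pair, the added ring nitrogen shifts the number by no more than the scatter. Nothing measured here speaks to the reason for this outcome. On these data alone, it remains open whether pyridin-4-yl, or a phenyl carrying a methoxy group or a carboxylic acid, would give a similar number at this position. As far as these compounds go, it also remains open whether pyridin-3-yl would do the same with the dimethylamino chains of compound 1 and compound 2.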